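From methyl to phenyl on a short-lived compound

The compounds below may be only part of what the source reports. "The series", "measured", "known", "first", "only" and "open" are said of these compounds alone.

Compound 1 `Cc1cc(CC2CCCCC2)n(O)c(=O)c1` gives < 0.0834 h
Compound 2 `Cc1cc(C2CCCCCC2)n(O)c(=O)c1` gives < 0.0834 h

In an ADME assay on microsomes from liver (Homo sapiens) for metabolic stability, read by LC-MS, using NADPH, tested at 2 uM (a lower number here means that the compound disappears faster, a higher number that the compound lasts longer), compound 1 gives < 0.0834 h as a limit of the assay, not a number. Compound 2 gives < 0.0834 h as a limit too. Compound 1 therefore has no exact place on the scale, and no order can be drawn between the two compounds: the limit of < 0.0834 h in this assay, at which 2 of the 2 values shown sit.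

Compound 3 `O=c1cc(-c2ccccc2)cc(CC2CCCCC2)n1O` has phenyl in place of methyl on an aromatic carbon, opposite the ring nitrogen (phenyl in place of methyl on an aromatic carbon). Within the data shown here, no measured pair shows what such a change does in this assay, so no step beyond the scatter is expected, in either direction. This expectation starts from compound 1 with its < 0.0834 h as a limit. The estimated change is a step that the limit leaves unreadable from compound 1 to compound 3 as expected half-life. For compound 3 the estimated half-life is 0.08 h with an expected range of 0.04 h to 0.2 h in repeat measurements.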

Compound 3, half-life: < 0.0834 h
Compound 3: only a limit was reported (the forecaster's own chance of this, stated with the estimate: 70%); the middle value does not contradict the limit.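

No step can be read between compound 1 and compound 3, since both give only a limit of the assay in this assay: the limit of < 0.0834 h in this assay, at which 3 of the 3 values shown sit.

On these data alone, the actual half-lives of compound 1, compound 2 and compound 3 stay open, and so does the effect of phenyl in place of methyl on an aromatic carbon.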